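The source may report more compounds than this note shows. Statements on the series, on what has been measured and on what is new or still open speak of the compounds shown alone.

Notes on the series. Compound 1 `CC1CCCCN1C(=S)SCc1ccc(C(=O)Nc2ccccc2N)cc1` gives 76.3% in a functional assay on HeLa cells (Homo sapiens) for antiproliferative activity, read by CCK-8 assay, with a stated time of 72 h, tested at 8 uM (a lower number here means a weaker effect, a higher number a stronger effect of the compound at the concentration tested), and compound 3 `Nc1ccccc1NC(=O)c1ccc(CSC(=S)N2CCCC2)cc1` gives 77.8%. Among the compounds with values here, the one step between measured neighbours, a number 1.5 percentage points higher from compound 1 to compound 3 (within the scatter), concerns the group on the thiocarbonyl carbon and stays within the scatter. Compound 2 `Nc1ccccc1NC(=O)c1ccc(CSC(=S)N2CCN(c3ccc(F)cc3)CC2)cc1` gives 64.5%, the lowest of the three numbers, beyond the scatter from compound 1 and from compound 3. Compound 4 `Cc1ccc(N2CCN(C(=S)SCc3ccc(C(=O)Nc4ccccc4N)cc3)CC2)cc1` differs from compound 2 by methyl in place of fluoro on an aromatic carbon. Within the data shown here, no measured step touches this position, so nothing among the three compounds speaks for or against a shift; the only guide is the value of compound 2 itself. The expected step is therefore a number 1.5 percentage points higher from compound 2 to compound 4 (within the scatter), none beyond the scatter. For compound 4 the estimate is 66%, range 52% to 80%.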

Compound 4, a percentage reported as inhibition, at one concentration (the size of the read-out at that concentration, not a potency): 24%
Beside the measured number, compound 4's estimate is 42 percentage points above it; the measured number lies below the stated range.
By their numbers in this assay, from the lowest: compound 4; then compound 2; then compounds 1 and 3 (each within the scatter of the next).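

The change from 4-fluorophenyl to 4-methylphenyl is not a silent one in this assay, with a number 40.5 percentage points lower from compound 2 to compound 4 (beyond the scatter). Within the data shown here, this place on the aromatic ring, para to a large group, therefore responds strongly to the exchange of a single heavy atom, whereas the only earlier step, a number 1.5 percentage points higher from compound 1 to compound 3 (within the scatter), concerned the group on the thiocarbonyl carbon. Nothing measured on these compounds explains the drop. Going by these compounds, it remains open whether a chloro or methoxy group at this place would read like fluoro or like methyl. On these data alone, an unsubstituted phenyl, which would show which of the two departs from the parent, is also open.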